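Sulfonyl ring swaps: working notes toward compound 4

This account rests on a few compounds, and the source may have more. Where it says the series, first, only, none or still open, it means among the compounds named here.

Measured so far:
compound 1 `CNCc1cc(-c2cccnc2F)n(S(=O)(=O)c2cccnc2)c1`, 96%
compound 2 `CNCc1cc(-c2cccnc2F)n(S(=O)(=O)c2ccsc2)c1`, 98%
compound 3 `CNCc1cn(S(=O)(=O)c2ncccc2C)c(-c2cccnc2F)c1F`, 54%

In a functional assay on the whole organism (strain Jcl:Sprague-Dawley) for inhibition, with Rattus norvegicus as the target, with stated times of 3 min and 3 h, at a dose of 1 mg/kg by the intravenous route (on this read-out higher numbers stand for more inhibition at the one dose given (going by the name of the read-out) and lower numbers for less inhibition), compound 3 gives the lowest of the three numbers; compound 1 and compound 2 both stand beyond the scatter above it. Compound 4 `CNCc1cn(S(=O)(=O)c2ccc(C)nc2)c(-c2cccnc2F)c1F` differs from compound 3 in one place: 6-methylpyridin-3-yl in place of 3-methylpyridin-2-yl on a sulfonyl sulfur. For the measured compounds named here, the only measured step on the sulfonyl ring, a number 2 percentage points higher from compound 1 to compound 2 (within the scatter), was within the scatter, but it was made on a core lacking the ring fluorine of compound 3 and exchanged one ring type for another, so it bears only loosely here. Going by the values given here, no step shows what exchanging one methylpyridinyl for another on this sulfur does. The expectation is therefore a step within the scatter, a number 1 percentage points higher from compound 3 to compound 4 (within the scatter), with a wide range. For compound 4 the estimate in this assay is 55%, from 25% to 82%.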

Compound 4, a percentage reported as inhibition, in the whole organism at one dose (the size of the read-out at that dose, not a potency): 97%
For compound 4 the middle estimate is 42 percentage points below the measured one, and the stated range ends below it.
By their numbers in this assay, from the lowest: compound 3; then compounds 1, 4 and 2 (each within the scatter of the next).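

Exchanging 3-methylpyridin-2-yl for 6-methylpyridin-3-yl on a sulfonyl sulfur, with the same atoms joined differently, goes with a number 43 percentage points higher from compound 3 to compound 4 (beyond the scatter) in this assay. The sulfonyl ring position is therefore sensitive to the arrangement of its atoms, which the earlier step within the scatter, between two different ring types, did not show. Nothing measured here explains the size of this step. Still open, going by these compounds, is whether a methoxy group or an amine in place of the methyl on the pyridine ring would keep this level of inhibition.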